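The compounds below may be only part of what the source reports. "The series", "measured", "known", "first", "only" and "open" are said of these compounds alone.

Measured so far in a toxicity assay on MT2 cells (Homo sapiens) for cytotoxicity, read by XTT assay, with a stated time of 4 days; on this read-out lower numbers stand for higher toxicity in this test and higher numbers for lower toxicity in this test:
- Compound 1 (`COc1ccc(CCOc2ccc(-c3c(C)nc(C)c([C@H](OC(C)(C)C)C(=O)O)c3N3CCC(C)(C)CC3)cc2)cc1`) gives >= 33500 nM as a limit
- Compound 2 (`Cc1nc(C)c([C@H](OC(C)(C)C)C(=O)O)c(N2CCC(C)(C)CC2)c1-c1ccc(OC2COCC2c2ccc(F)cc2)cc1`) gives >= 32000 nM; >= 32000 nM (2 entries) as a limit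
- Compound 3 (`Cc1ncsc1CCOc1ccc(-c2c(C)nc(C)c([C@H](OC(C)(C)C)C(=O)O)c2N2CCC(C)(C)CC2)cc1`) gives >= 25000 nM as a limit

Compound 3 thus stands at a limit (>= 25000 nM) and has no single number. Compound 4 (`Cc1nc(C)c(CCOc2ccc(-c3c(C)nc(C)c([C@H](OC(C)(C)C)C(=O)O)c3N3CCC(C)(C)CC3)cc2)s1`) differs from compound 3 by methyl in place of hydrogen on an aromatic carbon which turns 4-methyl-1,3-thiazol-5-yl into 2,4-dimethyl-1,3-thiazol-5-yl. Among the compounds with values here, the only measured step bearing on this group is a step that the two limits leave unreadable from compound 1 to compound 3 and it offers no size, so no step beyond the scatter is expected in this assay in either direction. The expected change is a step that the limit leaves unreadable from compound 3 to compound 4 as estimated here. For compound 4 the estimate is 28000 nM with an expected range from 14000 nM to 50000 nM and a report as a limit is likely.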

Compound 4, half-maximal cytotoxic concentration: >= 25000 nM
Compound 4: a limit, no number (the forecaster's own chance of this, stated with the estimate: 85%); the middle value is on the limit's open side.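

Within the data shown here, compound 1, compound 3 and compound 4 each stand only at a limit, so no new step to compound 4 can be read. The compounds shown leave open at what concentration any of them turns cytotoxic in this assay.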